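The compounds below may be only part of what the source reports. "The series", "measured", "known", "first", "only" and "open" are said of these compounds alone.

Measured compounds:
- compound 1, `Cc1ccc(NC(=O)c2ccc(/N=N\c3c[nH]c4ccccc34)cc2)cc1`: 300 nM
- compound 2, `Cc1ccc(NC(=O)c2ccc(/N=N\c3c[nH]c4ccccc34)cc2)c(C)c1`: 190000 nM
- compound 3, `COc1ccccc1NC(=O)c1ccc(/N=N\c2c[nH]c3ccccc23)cc1`: "not active" (no number reported)

In a functional assay on P388 cells (Mus musculus) for inhibition, read by MTT assay, with a stated time of 72 h (on this read-out higher numbers stand for weaker inhibition and lower numbers for stronger inhibition), compound 1 gives 300 nM. Compound 2 gives 190000 nM in this assay, and the step of a 630-fold higher number from compound 1 to compound 2 (2.80 log units; beyond the scatter) is a large one, brought about by a methyl in place of hydrogen on an aromatic carbon. Compound 3 stands apart from both: in this assay it is reported as "not active" (no number reported), so there is no single number for it, only the statement that no inhibition worth reporting was seen.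

Compound 4, `O=C(Nc1ccc(Cl)cc1)c1ccc(/N=N\c2c[nH]c3ccccc23)cc1`, is not yet measured. It differs from compound 3 by 4-chlorophenyl in place of 2-methoxyphenyl on an amide-type nitrogen. For the measured compounds named here, no measured step covers this exact change. Going by the values given here, the only step recorded, from compound 1 to compound 2, concerns a methyl on a different ring and is large, which shows that small changes on the ring attached to the amide nitrogen can move the result far. Compound 1 and compound 4 share a single group on that ring, while compound 3 and compound 2 are the weaker members. On this basis compound 4 is expected to land nearer to compound 1 than to compound 3, though with a wide range, at an estimated 2000 nM between 200 nM and 100000 nM.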

Compound 4, half-maximal inhibitory concentration: 80000 nM
Estimate against measurement, compound 4: 40-fold (1.60 log units) below; the range from low to high includes it.
By their numbers in this assay, from the lowest: compound 1; then compound 4; then compound 2.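

In this assay, chloro in place of methyl on an aromatic carbon gives a 270-fold higher number from compound 1 to compound 4 (2.43 log units; beyond the scatter) and thus shows that, on the ring carried by the amide-type nitrogen, the identity of a single group can decide most of the result, which the earlier step, where a second methyl was added, could not show. The change to 4-chlorophenyl in place of 2,4-dimethylphenyl on an amide-type nitrogen gives only a 2.4-fold lower number from compound 2 to compound 4 (0.38 log units; beyond the scatter) and leaves compound 4 far nearer to compound 2 than to compound 1, so compound 4 goes against the idea that a single group on this ring is enough for a low number. Compound 3 has no number, so the steps that would link it to the other compounds cannot be read.

From the compounds shown here alone, whether an amine or a carboxylic acid in place of the chloro would return the result toward that of compound 1, or move it further away, remains open. Nothing given here explains why methyl and chloro part so widely in this series.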